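This account rests on a few compounds, and the source may have more. Where it says the series, first, only, none or still open, it means among the compounds named here.

In a functional assay on A549 cells (Homo sapiens) for inhibition, read by colorimetric assay and MTT assay, with a stated time of 72 h (a higher number here means a weaker inhibitor, a lower number a stronger inhibitor), compound 1 (`Cc1ccc2c(c1)-c1cnc(n1C)OCCCCCCCCO2`) gives 41000 nM and compound 2 (`Cn1c2cnc1OCCCCCCCCCCOc1cc3ccccc3cc1-2`) gives 20000 nM while compound 3 (`C=CCCCCOc1ccccc1-c1cnc(OCCC=C)n1C`) gives 9000 nM as the lowest of the three numbers, beyond the scatter from both others. Compound 4 (`C=CCCCCOc1ccc(F)cc1-c1cnc(OCCC=C)n1C`) differs from compound 3 by fluoro in place of hydrogen on an aromatic carbon para to a (hex-5-en-1-yl)oxy group. For the measured compounds named here, no measured pair shows this kind of change, so the expectation in this assay is no step beyond the scatter and no firm direction. The expected step (a 1.1-fold lower number from compound 3 to compound 4 (0.05 log units; within the scatter)) stays within the scatter. For compound 4 the estimated value is 8000 nM with an expected range from 3500 nM to 18000 nM in this assay.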

Compound 4, half-maximal inhibitory concentration: 61000 nM
Beside the measured number, compound 4's estimate is 7.6-fold (0.88 log units) below it, outside the stated range (above it).
By their numbers in this assay, from the lowest: compound 3; then compound 2; then compounds 1 and 4 (each within the scatter of the next).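

In this assay, for the compounds shown here, fluoro in place of hydrogen on an aromatic carbon, para to a (hex-5-en-1-yl)oxy group, gives a 6.8-fold higher number from compound 3 to compound 4 (0.83 log units; beyond the scatter), the first step that can be read at a single place. This position is therefore not indifferent to substitution: a single fluorine atom is enough to weaken inhibition. Nothing shown accounts for the size of this step. Still open, from the compounds shown here alone, is whether the loss is specific to fluoro or also follows with chloro, methoxy or an amine at this position.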